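The source may hold more compounds than are shown below. What is called first, only, known or untested is meant among the compounds shown, and "the series" means these compounds.

Two close relatives of the same flavone-like scaffold have been tested in a functional assay on BV-2 cells (Mus musculus) for inhibition; a lower number here means a stronger inhibitor, a higher number a weaker inhibitor. Compound 1, `COc1ccc(-c2coc3cc(OCC=C(C)C)cc(O)c3c2=O)cc1OC`, carries a hydroxyl on its core together with a prenyl ether and two methoxy groups on the pendant aromatic ring; in this assay compound 1 gave no number at all but only a limit of > 50000 nM, and that limit is a point at which values shown so far sit (the limit of > 50000 nM in this assay, at which 1 of the 2 values shown sits). Going by the values given here, compound 2, `COc1ccc(-c2coc3cc(OCC=C(C)C)ccc3c2=O)cc1`, lacks that hydroxyl and has only one methoxy on the pendant ring; in this assay compound 2 gives 45200 nM, which is the single measured number available, so it stands alone on the scale with no step to compare it against.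

Compound 3, `COc1ccc(-c2coc3cc(OCC=C(C)C)ccc3c2=O)cc1OC`, has not yet been measured. It is compound 2 with one change: methoxy in place of hydrogen on an aromatic carbon. Because compound 1 sits at the limit of > 50000 nM, and compound 3 shares its two methoxy groups while dropping only the hydroxyl, weak inhibition is expected again. The step of a 1.0-fold lower number from compound 2 to compound 3 (0.00 log units; within the scatter) is estimated to be small, of no fixed direction, and likely within the usual scatter. Compound 3 is expected to give 45000 nM, between 15000 nM and 150000 nM.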

Compound 3, half-maximal inhibitory concentration: 36900 nM
The estimate for compound 3 lay 1.2-fold (0.09 log units) above the measured number; measured number inside the range.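

A methoxy in place of hydrogen on this aromatic carbon, ortho to a methoxy group, leaves no readable mark in this assay: the result is a 1.2-fold lower number from compound 2 to compound 3 (0.09 log units; within the scatter), so the extra methoxy can be added here without a measurable gain or loss in this assay. The second comparison, hydrogen in place of hydroxy on an aromatic carbon of the core, also shows nothing beyond the scatter so far, and it reads an at least 1.3-fold lower number from compound 1 to compound 3 (0.13 log units; that floor lies within the scatter). Compound 1 carries a limit and not a number, so this step is only a floor and its true size stays unknown: the limit of > 50000 nM in this assay, at which 1 of the 3 values shown sits.

Methoxy is the only group shown at this position, so it remains open whether an amine, a carboxylic acid or a longer alkoxy chain on the same aromatic carbon would move the number beyond the scatter. All three compounds also carry the same prenyl ether, which leaves open how a shorter chain or a free hydroxy in its place would read in this assay.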